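A few compounds are considered here, and "the series" means these few. Any claim that something is new, unique, unknown or untested is made for them only; others in the source may bear on it.

Measured compounds:
compound 1, `CCCc1nc(C)c2c(C)nn(CCC)c(=O)n12`, > 48000 nM in a functional assay for inhibition, with Homo sapiens as the target; a higher number here means a weaker inhibitor, a lower number a stronger inhibitor
compound 2, `C=CCn1ncc2c(C)nc(Cc3ccccc3)n2c1=O`, > 48000 nM in this assay

Compound 1 carries a propyl chain on one of its ring nitrogens and propyl on the carbon across the core; in this assay it reaches only the upper limit of what the assay can report, > 48000 nM, so no true number is known for it. Compound 2, a related compound with an allyl group on the ring nitrogen and a benzyl group on the core, likewise sits at a limit, > 48000 nM. Both values shown are limits of this kind: the limit of > 48000 nM in this assay, at which 2 of the 2 values shown sit. Within the data shown here, compound 1 therefore stands nowhere in particular on a scale; it is simply a weak inhibitor, with no measured step from which a trend could be drawn.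

Compound 3, `CCCc1nc(C)c2c(C)nn(CC(O)CO)c(=O)n12`, differs from compound 1 in one place: 1,2-dihydroxyethyl in place of ethyl on a saturated chain carbon bound to an aromatic nitrogen, or, cut one bond further out, propyl to 2,3-dihydroxypropyl. Among the measured compounds shown here, no measured pair shows what such a change does here, so no direction is foretold, and the step from compound 1 to compound 3, a step that the limit leaves unreadable from compound 1 to compound 3, is expected to stay within the scatter. Compound 3 is expected to give about 60000 nM, in the range 20000 nM to 200000 nM, most likely again reported only as a limit.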

Compound 3, half-maximal inhibitory concentration: > 48000 nM
Compound 3: no number, only a limit; the forecaster's own chance of this, stated with the estimate: 80%; the middle value does not contradict the limit.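

Compound 1 and compound 3 both give only a limit, not a true number, so the step between them cannot be read: the limit of > 48000 nM in this assay, at which 3 of the 3 values shown sit.

The compounds shown leave open whether any of these structures gives a true number in this assay, and what swapping ethyl for 1,2-dihydroxyethyl actually does.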